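A few compounds are considered here, and "the series" means these few. Any claim that something is new, unique, unknown or untested is made for them only; others in the source may bear on it.

Compound 1 `C=C(Br)C(=O)Nc1cccc(-c2cn3nc(Cc4ccc(OC)cc4)sc3n2)c1` gives 1400 nM in a functional assay on L1210 cells (Mus musculus) for inhibition, read by cell counting, with a stated time of 2 days; a lower number here means a stronger inhibitor, a higher number a weaker inhibitor.
Compound 2 `C=C(Br)C(=O)Nc1cccc(-c2cn3nc(-c4cccs4)sc3n2)c1` gives 170 nM.
Compound 3 `C=C(Br)C(=O)Nc1cccc(-c2cn3nc(Cc4ccc(Cl)cc4)sc3n2)c1` gives 2300 nM.

Compound 3 has the highest number of the three, though its gap to compound 1 lies within the scatter; only its gap to compound 2 lies beyond it. Compound 4 `C=C(Br)C(=O)Nc1cccc(-c2cn3nc(-c4ccc(F)cc4)sc3n2)c1` has not been measured yet. It differs from compound 3 by 4-fluorophenyl in place of 4-chlorobenzyl on an aromatic carbon. Among the measured compounds shown here, two measured steps bear on this change: a 14-fold higher number from compound 2 to compound 3 (1.13 log units; beyond the scatter) and an 8.2-fold lower number from compound 1 to compound 2 (0.92 log units; beyond the scatter). In both, a ring joined directly to the shared core gave a lower number than a benzyl group, though this rests on two steps only. A lower number is therefore expected for compound 4, with a 7.7-fold lower number from compound 3 to compound 4 (0.88 log units; beyond the scatter). The estimate for compound 4 in this assay is 300 nM, with a range from 100 nM to 1000 nM.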

Compound 4, half-maximal inhibitory concentration: 250 nM
Beside the measured number, compound 4's estimate is 1.2-fold (0.08 log units) above it, within the range that was stated.
By their numbers in this assay, from the lowest: compounds 2 and 4 (each within the scatter of the next); then compounds 1 and 3 (each within the scatter of the next).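

In this assay, the lower number seen with thiophen-2-yl now extends to a six-membered ring joined directly to the shared core: a 9.2-fold lower number from compound 3 to compound 4 (0.96 log units; beyond the scatter) and a 5.6-fold lower number from compound 1 to compound 4 (0.75 log units; beyond the scatter) both favour 4-fluorophenyl over the benzyl groups. Against thiophen-2-yl, a 1.5-fold higher number from compound 2 to compound 4 (0.17 log units; within the scatter) leaves the two directly joined rings indistinguishable at this position.

On these data alone, since 4-fluorophenyl differs from 4-chlorobenzyl in both the benzyl carbon and the halogen, the share of each stays open, as does how an amine on that ring or a longer chain would read. Nothing measured here gives a reason for these steps.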